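Chloro to methoxy on compound 3

The source may hold more compounds than are shown below. What is called first, only, known or untested is meant among the compounds shown, and "the series" means these compounds.

Values measured so far in an ADME assay (liver) for metabolic stability, with Liver microsome (Rattus norvegicus) as the target, read by LC-MS, using microsomes, with a stated time of 30 min, tested at 4 uM (on this read-out higher numbers stand for a more stable compound and lower numbers for a less stable compound), are these

compound 1 `CCN1CCN(c2nc(C)nc3c2nc(-c2ccccc2Cl)n3CCOC)CC1` gives 53%
compound 2 `CC(=O)NCCn1c(-c2ccccc2Cl)nc2c(N3CCN(C)CC3)nc(C)nc21` gives 0%
compound 3 `Cc1nc(N2CCN(C)CC2)c2nc(-c3cccc(Cl)c3)n(C3CCOCC3)c2n1` gives 45%

Among the compounds with values here, compound 3 reads 45% in this assay here, a number within the usual scatter of the one for compound 1 and well beyond the scatter above the one for compound 2. Compound 4 `COc1cccc(-c2nc3c(N4CCN(C)CC4)nc(C)nc3n2C2CCOCC2)c1` has not yet been measured. It differs from compound 3 in a single place, with methoxy in place of chloro on an aromatic carbon so that 3-chlorophenyl becomes 3-methoxyphenyl.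

Within the data shown here, no two measured compounds differ in one place only, so the data give no direct guide to the size of this swap. The expectation therefore starts from compound 3 at 45% and keeps a wide range, since compound 2 at 0% shows how low these compounds can read. The estimated change is small and downward, with a number 9 percentage points lower from compound 3 to compound 4 (within the scatter) expected, a shift that stays within the usual scatter. Compound 4 is estimated to give 36% with a range from 18% to 52% as the expected span.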

Compound 4, percent of the compound remaining: 30%
For compound 4 the middle estimate is 6 percentage points above the measured one; the range from low to high includes it.
By their numbers in this assay, from the lowest: compound 2; then compound 4; then compounds 3 and 1 (each within the scatter of the next).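

Compound 3 and compound 4 are the only pair shown that differ in one place, so the size of a single change can be read directly in this assay for this series. Methoxy in place of chloro on this aromatic carbon gives a number 15 percentage points lower from compound 3 to compound 4 (beyond the scatter) as a modest but real step, larger than repeated measurements alone would be expected to produce. The group at this place therefore matters for the read-out, even though the swap only replaces one heavy atom with two and adds one hydrogen-bond acceptor, and compound 4 still reads 30% rather than falling to nothing.

Nothing shown explains why the number falls, and it remains unclear whether the loss of chlorine or the arrival of methoxy matters more. With only chloro and methoxy shown at this place, it remains open how a smaller atom such as fluorine, a nitrile, or a longer chain such as ethoxy would read on the same ring.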